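Hydrazone aryl variation on the shared core

A few compounds are considered here, and "the series" means these few. Any claim that something is new, unique, unknown or untested is made for them only; others in the source may bear on it.

Going by the values given here, compound 3 `CN(C)CCn1cnnc1-c1cc(Oc2ccc(NC(=O)N/N=C/c3cccc(Br)c3)cc2F)ccn1` gives 520 nM in a functional assay on NCI-H460 cells (Homo sapiens) for cytotoxicity, read by MTT assay, with a stated time of 72 h (a higher number here means a weaker inhibitor, a lower number a stronger inhibitor), the second highest of three numbers so far. Compound 1 `CN(C)CCn1cnnc1-c1cc(Oc2ccc(NC(=O)N/N=C/c3c(Cl)cccc3Cl)cc2F)ccn1` gives 350 nM, and the difference is a 1.5-fold higher number from compound 1 to compound 3 (0.17 log units; within the scatter). Compound 2 `CN(C)CCn1cnnc1-c1cc(Oc2ccc(NC(=O)N/N=C/c3ccccc3O[N+](=O)[O-])cc2F)ccn1` gives 1270 nM, and the difference is a 2.4-fold lower number from compound 2 to compound 3 (0.39 log units; beyond the scatter). All three changes sit on the carbon with a double bond to nitrogen; the widest spread among them is a 3.6-fold higher number from compound 1 to compound 2 (0.56 log units; beyond the scatter). Compound 4 `CN(C)CCn1cnnc1-c1cc(Oc2ccc(NC(=O)N/N=C/c3cc(Br)c(O)c(Br)c3)cc2F)ccn1` carries 3,5-dibromo-4-hydroxyphenyl in place of 3-bromophenyl on a carbon with a double bond to nitrogen. The steps from compound 1 and from compound 2 to compound 3 bear on this, both modest or within scatter, so only a small step in this assay is expected, direction uncertain. For compound 4 the estimate is 600 nM, range 250 nM to 1500 nM. This expected step is a 1.2-fold higher number from compound 3 to compound 4 (0.06 log units; within the scatter).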

Compound 4, half-maximal inhibitory concentration: 3760 nM
Estimate against measurement, compound 4: 6.3-fold (0.80 log units) below; the whole stated range lies below it.
By their numbers in this assay, from the lowest: compounds 1 and 3 (each within the scatter of the next); then compound 2; then compound 4.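

In this assay the carbon with a double bond to nitrogen tolerates less than the earlier aryl changes suggested: 3,5-dibromo-4-hydroxyphenyl gives a 7.2-fold higher number from compound 3 to compound 4 (0.86 log units; beyond the scatter) and also a 3.0-fold higher number from compound 2 to compound 4 (0.47 log units; beyond the scatter) and an 11-fold higher number from compound 1 to compound 4 (1.03 log units; beyond the scatter) in the series. Compound 4 therefore has the highest number of the four, with all three steps beyond the scatter. No available evidence bears on this result. Whether the hydroxyl or the added bromine accounts for the step remains open. A methoxy group in place of that hydroxyl is also untested among the compounds shown.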